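Removing a Methoxy Group From Compound 3

The source may report more compounds than this note shows. Statements on the series, on what has been measured and on what is new or still open speak of the compounds shown alone.

Compound 3 `C=CC1=C(C(=O)NCCC)C(c2ccc(OC)c(OC)c2)OC1` is characterised so far only by a limit in a functional assay on QGY7701 cells (Homo sapiens) for cytotoxicity, read by MTT assay, with a stated time of 24 h; a higher number here means a weaker inhibitor, a lower number a stronger inhibitor. In this assay compound 3 gives > 100000 nM, which is a limit of the assay rather than a number. Two related compounds stand the same way. Compound 1 `C=CC1=C(C(=O)NCc2ccccc2)C(c2ccc(OC)cc2)OC1` gives > 100000 nM in this assay, again a limit. Compound 2 `C=CC1=C(C(=O)NC2CCCCC2)C(c2ccc(OC)cc2)OC1` gives > 100000 nM in this assay, also a limit. For the measured compounds named here, the exchange of benzyl for cyclohexyl on the amide-type nitrogen, a step that the two limits leave unreadable from compound 1 to compound 2, therefore cannot be read in size, and the only evidence on the measured compounds is the limit of > 100000 nM in this assay, at which 3 of the 3 values shown sit.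

Compound 4 `C=CC1=C(C(=O)NCCC)C(c2ccc(OC)cc2)OC1` differs from compound 3 by hydrogen in place of methoxy on an aromatic carbon. Going by the values given here, no measured step involves such a change, and none of the measured steps is readable in size, so nothing among them points to a gain or a loss beyond the scatter. Among the compounds with values here, because every value so far sits at the limit of > 100000 nM in this assay, at which 3 of the 3 values shown sit, compound 4 is expected to give 150000 nM in this assay, with a range from 50000 nM to 1000000 nM, and most probably to be reported once more as a limit. The step from compound 3 to compound 4 that this estimate means is expected to be a step that the limit leaves unreadable from compound 3 to compound 4.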

Compound 4, half-maximal inhibitory concentration: > 100000 nM
Compound 4 gave a limit, no number; the forecaster's own chance of this, stated with the estimate: 85%; the middle value lies beyond the limit too.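

Compound 4 also gives only a limit in this assay, so none of its steps to compound 1, compound 2 or compound 3 can be read in size. The compounds shown leave open how large any change among them is, and whether any one of them is a stronger inhibitor than another: the limit of > 100000 nM in this assay, at which 4 of the 4 values shown sit.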